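Methylsulfanyl for methoxy on the ethynyl-bearing core

The source may report more compounds than this note shows. Statements on the series, on what has been measured and on what is new or still open speak of the compounds shown alone.

Compound 1 `COc1ncnc2c1c(-c1ccoc1)cn2[C@@H]1O[C@H](CO)[C@@H](O)[C@H]1O` in a functional assay on HL-60 cells (Homo sapiens) for antiproliferative activity, read by XTT assay, with a stated time of 72 h (a higher number here means a weaker inhibitor, a lower number a stronger inhibitor), gives 150 nM. Compound 2 `CSc1ncnc2c1c(-c1ccoc1)cn2[C@@H]1O[C@H](CO)[C@@H](O)[C@H]1O` carries the change methylsulfanyl in place of methoxy on an aromatic carbon and in this assay gives 360 nM, a step of a 2.4-fold higher number from compound 1 to compound 2 (0.38 log units; beyond the scatter). Compound 3 `C#Cc1cn([C@@H]2O[C@H](CO)[C@@H](O)[C@H]2O)c2ncnc(OC)c12` differs from compound 1 by ethynyl in place of furan-3-yl on an aromatic carbon; in this assay compound 3 gives 190 nM, a step of a 1.3-fold higher number from compound 1 to compound 3 (0.10 log units; within the scatter), so the two cores sit close together. Compound 4 `C#Cc1cn([C@@H]2O[C@H](CO)[C@@H](O)[C@H]2O)c2ncnc(SC)c12` is not yet measured; it differs from compound 3 by methylsulfanyl in place of methoxy on an aromatic carbon, the same change as that from compound 1 to compound 2, with the place described in identical words. Within the data shown here, for compound 4 the expected step of a 2.4-fold higher number from compound 3 to compound 4 (0.37 log units; beyond the scatter) rests on the single measured instance of this change, a 2.4-fold higher number from compound 1 to compound 2 (0.38 log units; beyond the scatter). Compound 4 is therefore expected to give about 450 nM in this assay, plausibly between 200 nM and 1000 nM.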

Compound 4, half-maximal inhibitory concentration: 50 nM
Estimate against measurement, compound 4: 9.0-fold (0.95 log units) above; the measured number lies below the stated range.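

On the ethynyl-bearing core, methylsulfanyl in place of methoxy gives a 3.8-fold lower number from compound 3 to compound 4 (0.58 log units; beyond the scatter) in this assay, so the direction seen on the furan-3-yl core reverses: the same change on two cores in this assay, a 2.4-fold higher number (0.38 log units; beyond the scatter) from compound 1 to compound 2 and a 3.8-fold lower number (0.58 log units; beyond the scatter) from compound 3 to compound 4, 9.1-fold (0.96 log units) apart, beyond the scatter of two such steps. Ethynyl in place of furan-3-yl likewise depends on the group at the other place, with a 7.2-fold lower number from compound 2 to compound 4 (0.86 log units; beyond the scatter) in the methylsulfanyl pair and a step within the scatter in the methoxy pair: the same change on two cores in this assay, a 1.3-fold higher number (0.10 log units; within the scatter) from compound 1 to compound 3 and a 7.2-fold lower number (0.86 log units; beyond the scatter) from compound 2 to compound 4, 9.1-fold (0.96 log units) apart, beyond the scatter of two such steps. The two changes therefore do not carry independently between these cores, but with a single pair on each core this does not show why, or how general the reversal is.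

The compounds shown leave open how an amine or ethylsulfanyl in place of methoxy would behave on either core. On these data alone, whether a nitrile in place of ethynyl would show the same dependence also remains open.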